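This account rests on a few compounds, and the source may have more. Where it says the series, first, only, none or still open, it means among the compounds named here.

Three compounds have been measured in a functional assay on HCT-116 cells (Homo sapiens) for antiproliferative activity, read by MTT assay, with a stated time of 48 h; a higher number here means a weaker inhibitor, a lower number a stronger inhibitor:

compound 1 `Cc1ccccc1C(=O)Nc1cccc(/C=C/C(=O)c2nc3ccccc3[nH]2)c1` gives 1870 nM
compound 2 `Cc1cccc(C(=O)Nc2cccc(/C=C/C(=O)c3nc4ccccc4[nH]3)c2)c1` gives 1420 nM
compound 3 `COc1cccc(C(=O)Nc2cccc(/C=C/C(=O)c3nc4ccccc4[nH]3)c2)c1` gives 3680 nM

Among these, compound 3 carries the highest number. Its step from compound 1 is small, a 2.0-fold higher number from compound 1 to compound 3 (0.29 log units; within the scatter), and lies within the scatter, whereas the step of a 2.6-fold higher number from compound 2 to compound 3 (0.41 log units; beyond the scatter) is the only one of the set beyond it. The steps of a 1.3-fold lower number from compound 1 to compound 2 (0.12 log units; within the scatter) and a 2.0-fold higher number from compound 1 to compound 3 (0.29 log units; within the scatter) are both within the scatter.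

Compound 4 `Cc1cccc(S(=O)(=O)Nc2cccc(/C=C/C(=O)c3nc4ccccc4[nH]3)c2)c1` differs from compound 3 in one place: (3-methylphenyl)sulfonyl in place of (3-methoxyphenyl)carbonyl on a nitrogen on an aromatic ring. Two parts of this change can be weighed separately. Going by the values given here, the return from methoxy to methyl on the aromatic carbon reverses the one step beyond the scatter, a 2.6-fold higher number from compound 2 to compound 3 (0.41 log units; beyond the scatter), which by itself points to a modestly lower number in this assay. Among the compounds with values here, for the sulfonyl in place of the carbonyl no measured step exists, so that part of the change is unknown and widens the range. Compound 4 is therefore estimated at 1800 nM, within a range from 600 nM to 5500 nM. For compound 4 the expected step is a 2.0-fold lower number from compound 3 to compound 4 (0.31 log units; beyond the scatter), a modest move downward.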

Compound 4, half-maximal inhibitory concentration: 597 nM
Compound 4: the middle estimate sits 3.0-fold (0.48 log units) above what was measured; the measured number lies below the stated range.
By their numbers in this assay, from the lowest: compound 4; then compounds 2, 1 and 3 (each within the scatter of the next, the first and the last beyond it).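

The cleanest reading of the sulfonyl in place of the carbonyl comes from a 2.4-fold lower number from compound 2 to compound 4 (0.38 log units; beyond the scatter) in this assay, where the methyl group stays unchanged, so at this place, on a nitrogen on an aromatic ring, the change lowers the number. The larger 6.2-fold lower number from compound 3 to compound 4 (0.79 log units; beyond the scatter) also includes methyl in place of methoxy, and a 3.1-fold lower number from compound 1 to compound 4 (0.50 log units; beyond the scatter) also includes 3-methylphenyl in place of 2-methylphenyl, so neither isolates the sulfonyl. Going by these compounds alone, compound 4 is the only compound whose steps to all the others lie beyond the scatter.

Nothing available explains why the sulfonyl gives the lower number. Also open, on these data alone, is whether the same change holds with 3-methoxyphenyl or 2-methylphenyl on the sulfonyl, or with an amine or a carboxylic acid on its ring.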